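Swapping the Amine Side Group for an Acid

This account rests on a few compounds, and the source may have more. Where it says the series, first, only, none or still open, it means among the compounds named here.

Compound 1 `COc1ccc(NC(=O)c2ccc(OCCCCl)c([N+](=O)[O-])c2)cc1`: 39700 nM
Compound 2 `COc1ccc(C(=O)Nc2ccc(N(C)C)cc2)cc1[N+](=O)[O-]`: 88200 nM
Compound 3 `CN(C)C1CCN(Cc2ccc(NC(=O)c3ccc(OCCCCl)c([N+](=O)[O-])c3)cc2C(F)(F)F)C1`: 5800 nM

In a toxicity assay on Huh-7.5 cells (Homo sapiens) for inhibition, read by MTT assay, with a stated time of 96 h (a lower number here means that less compound is tolerated, a higher number that more compound is tolerated), compound 3 has the lowest number of the three, at 5800 nM. Even the nearest, compound 1 at 39700 nM, lies beyond the usual scatter from it. Compound 4 `O=C(Nc1ccc(CN2CC(C(=O)O)C2)c(C(F)(F)F)c1)c1ccc(OCCCCl)c([N+](=O)[O-])c1` has 3-carboxyazetidin-1-yl in place of 3-(dimethylamino)pyrrolidin-1-yl on a saturated chain carbon bound to an aromatic carbon. Within the data shown here, no two measured compounds differ in only one place, so no direct precedent exists for this swap. The closest guide is indirect: compound 1, which has no 3-(dimethylamino)pyrrolidin-1-yl, gives 39700 nM. Losing that group from compound 3 is therefore expected to raise the number in this assay, meaning more compound is tolerated, by a step beyond the scatter. The expected change is a 5.2-fold higher number from compound 3 to compound 4 (0.71 log units; beyond the scatter). The estimated value for compound 4 is 30000 nM, with an expected range of 11000 nM to 80000 nM.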

Compound 4, half-maximal cytotoxic concentration: > 200000 nM
Compound 4 gave a limit, no number; the forecaster's own chance of this, stated with the estimate: 15%; middle value at least 6.6-fold (0.82 log units) from the limit.
By their numbers in this assay, from the lowest: compound 3; then compound 1; then compound 2. At a limit, above all of these: compound 4.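

In this assay, compound 4 sits at a limit of the assay, > 200000 nM, and not at a measured number. Among these compounds, this is the first comparison here of compounds differing in one place: the 3-(dimethylamino)pyrrolidin-1-yl group gives way to 3-carboxyazetidin-1-yl, and this single change produces an at least 34-fold higher number from compound 3 to compound 4 (1.53 log units; beyond the scatter). The full size of the step remains unknown because one end of it is a limit: the limit of > 200000 nM in this assay, at which 1 of the 4 values shown sits.

This one swap changes the ring and the attached group together, so the compounds shown cannot separate those two changes; a 3-carboxypyrrolidin-1-yl group or a 3-(dimethylamino)azetidin-1-yl group in the same place would pull them apart. The methyl ester of the carboxylic acid would test whether the free acid itself matters.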